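Working notes: the chain end of compound 1

The source may hold more compounds than are shown below. What is called first, only, known or untested is meant among the compounds shown, and "the series" means these compounds.

- compound 1 `CCCCCCCCC(=O)Nc1nc2ccccc2n1CCC` gives 5.7
- compound 2 `CCCn1c(NC(=O)/C=C/c2ccccc2)nc2ccccc21` gives 4.6

In a physicochemical assay for lipophilicity (a higher number here means a more lipophilic compound, a lower number a more polar compound), compound 1 stands highest of the two measured compounds, with compound 2 lower by more than the scatter. Compound 3 `CCCn1c(NC(=O)CCCc2ccccc2)nc2ccccc21` awaits measurement. The change from compound 1 to compound 3 (phenyl in place of pentyl on a saturated chain carbon, three bonds along the chain from a carbonyl carbon) is phenyl in place of pentyl on a saturated chain carbon, three bonds along the chain from a carbonyl carbon. Among the measured compounds shown here, no measured pair shows this change alone. For the measured compounds named here, compound 2 at 4.6 also carries phenyl on its chain and is the only guide. A fall beyond the scatter is expected in this assay (estimated step a number 0.80 log units lower from compound 1 to compound 3 (beyond the scatter)). Compound 3 is estimated at 4.9 (expected range 4.5 to 5.3).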

Compound 3, partition coefficient: 5
Compound 3: middle estimate off by 0.10 log units, on the low side; low and high end bracket the measured number.
By their numbers in this assay, from the lowest: compound 2; then compound 3; then compound 1.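

In this assay the first pair differing in one place puts a size on phenyl in place of pentyl on a saturated chain carbon, three bonds along the chain from a carbonyl carbon (a number 0.70 log units lower from compound 1 to compound 3 (beyond the scatter)). The number of compound 3 falls even though phenyl brings 6 heavy atoms against 5 for pentyl, with the shared core unchanged. Nothing measured here speaks to the reason for this fall.

Open, going by these compounds, is how a longer chain ending in phenyl, or an amine or a carboxylic acid at the chain end, would stand in this assay against compound 3. A single pair also leaves open whether the step holds elsewhere on the core.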